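The compounds below may be only part of what the source reports. "The series", "measured", "known", "first", "only" and "open" are said of these compounds alone.

In a functional assay on the whole organism (strain Wistar) for inhibition, with Rattus norvegicus as the target, read by paw edema, with stated times of 60 min and 3 h, at a dose of 100 mg/kg by the oral route (on this read-out higher numbers stand for more inhibition at the one dose given (going by the name of the read-out) and lower numbers for less inhibition), compound 1 `COc1cc2c(cc1OC)C(CC(N)=O)CC2` gives 30.4% and compound 2 `CCCCCNC(=O)CC1CCc2cc(OC)c(OC)cc21` gives 37.7%, which is the higher of the two numbers in hand, though the step of a number 7.3 percentage points higher from compound 1 to compound 2 (within the scatter) lies within the scatter. Compound 3 `COc1cc2c(cc1OC)C(CC(=O)N1CCOCC1)CC2` carries morpholin-4-yl in place of pentylamino on a carbonyl carbon. Going by the values given here, the only measured step, a number 7.3 percentage points higher from compound 1 to compound 2 (within the scatter), concerns a substituent on the amide nitrogen and is within the scatter, so for compound 3 a step beyond the scatter is not expected in either direction. Compound 3 is therefore estimated at 33% in this assay, with a range of 18% to 48%, meaning an expected step of a number 4.7 percentage points lower from compound 2 to compound 3 (within the scatter).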

Compound 3, a percentage reported as inhibition, in the whole organism at one dose (the size of the read-out at that dose, not a potency): 19.6%
Estimate against measurement, compound 3: 13.4 percentage points above, within the range that was stated.
By their numbers in this assay, from the lowest: compound 3; then compounds 1 and 2 (each within the scatter of the next).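

Unlike the step from amino to pentylamino, which stayed within the scatter, this change shows that the group on the carbonyl carbon can move the read-out beyond it in this assay. Morpholin-4-yl gives a number 18.1 percentage points lower from compound 2 to compound 3 (beyond the scatter) in place of pentylamino and a number 10.8 percentage points lower from compound 1 to compound 3 (beyond the scatter) in place of amino.

The compounds shown leave open whether the ring, its oxygen or the missing amide hydrogen counts, which piperidin-1-yl or dimethylamino on the same carbonyl carbon could help separate. No measurement given here explains the lower number.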